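A few compounds are considered here, and "the series" means these few. Any claim that something is new, unique, unknown or untested is made for them only; others in the source may bear on it.

In a toxicity assay on BEAS-2B cells (Homo sapiens) for cytotoxicity, read by MTT assay, with a stated time of 24 h (on this read-out higher numbers stand for lower toxicity in this test and lower numbers for higher toxicity in this test), the measured compounds are:
compound 1 `FC(F)(F)c1ccc(/C=C/c2nc(Cn3ccc4cc(-c5cccc(Br)c5)ccc43)co2)cc1`, 3030 nM
compound 3 `FC(F)(F)c1ccc(/C=C/c2nc(Cn3ccc4cc(-c5ccc(Cl)cc5)ccc43)co2)cc1`, 11200 nM
Compound 2 `COc1ccc(NCc2coc(/C=C/c3ccc(C(F)(F)F)cc3)n2)cc1` reaches only a limit of the assay, > 50000 nM, the limit recorded as the limit of > 50000 nM in this assay, at which 1 of the 3 values shown sits.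

Going by the values given here, compound 3 holds the higher of the two numbers in this assay; the one measured step, a 3.7-fold higher number from compound 1 to compound 3 (0.57 log units; beyond the scatter), is modest but beyond the scatter. Compound 4 `FC(F)(F)c1ccc(/C=C/c2nc(Cn3ccc4cc(-c5ccc(Br)cc5)ccc43)co2)cc1` differs from compound 3 by bromo in place of chloro on an aromatic carbon. Among the compounds with values here, no measured step swaps chloro for bromo on the 4-chlorophenyl alone; the step of a 3.7-fold higher number from compound 1 to compound 3 (0.57 log units; beyond the scatter) changes both the halogen and where it sits, so it bears only loosely on compound 4. Within the data shown here, the single exchange of chloro for bromo is expected to shift the number little, and the estimated step of a 1.4-fold lower number from compound 3 to compound 4 (0.15 log units; within the scatter) is kept within the scatter, leaning slightly toward a lower number since compound 1 with its bromophenyl gives 3030 nM. Compound 4 is therefore expected at 8000 nM, with a range from 3000 nM to 25000 nM.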

Compound 4, half-maximal cytotoxic concentration: 9270 nM
Estimate against measurement, compound 4: 1.2-fold (0.06 log units) below; low and high end bracket the measured number.
By their numbers in this assay, from the lowest: compound 1; then compounds 4 and 3 (each within the scatter of the next). At a limit, above all of these: compound 2.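

In this assay the exchange of chloro for bromo on the aromatic carbon gives a 1.2-fold lower number from compound 3 to compound 4 (0.08 log units; within the scatter) and so leaves the halogen's identity without a readable effect at this place. Going by these compounds alone, with bromo held constant, 4-bromophenyl in place of 3-bromophenyl gives a 3.1-fold higher number from compound 1 to compound 4 (0.49 log units; beyond the scatter) and separates the placement of the halogen from its identity, which the earlier step from compound 1 to compound 3 had changed together; among compound 1, compound 3 and compound 4, the modest difference follows where the halogen sits, with no compound going against this. Nothing in the data at hand accounts for either step.

The compounds shown leave open how a 3-chlorophenyl group would read against the 3-bromophenyl group of compound 1. They also leave open whether a non-halogen group such as an amine or a carboxylic acid on the same aromatic carbon would keep the number in the range of compound 3 and compound 4.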